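Adding a methoxy to the compound 2 scaffold

A few compounds are considered here, and "the series" means these few. Any claim that something is new, unique, unknown or untested is made for them only; others in the source may bear on it.

Compound 1 `COc1cc(OC)cc(-c2cccc(NC(=O)CCc3ccc4c(c3)B(O)OC4)c2)c1`: 29000 nM
Compound 2 `COc1cccc(-c2cccc(NC(=O)CCc3ccccc3)c2)c1`: 24000 nM
Compound 3 `COc1cc(OC)cc(-c2cccc(NC(=O)CCc3ccccc3)c2)c1`: not yet measured

In a functional assay on SK-OV-3 cells (Homo sapiens) for antiproliferative activity, read by MTT assay, with a stated time of 72 h (on this read-out higher numbers stand for weaker inhibition and lower numbers for stronger inhibition), compound 1 gives 29000 nM and compound 2 gives 24000 nM within the scatter of each other. Among the measured compounds shown here, compound 2 therefore stands level with the only other measured compound, and the data show no separation between the two.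

The change from compound 2 to compound 3 is methoxy in place of hydrogen on an aromatic carbon and amounts to methoxy in place of hydrogen on an aromatic carbon. For the measured compounds named here, no measured pair isolates this change, so the expectation rests on thin evidence. Compound 1 at 29000 nM is the nearest guide, since it carries the same methoxy groups as compound 3, although it differs from compound 3 elsewhere in the structure. No step beyond the scatter is expected, and no direction can be called with confidence. The estimated change is a 1.1-fold lower number from compound 2 to compound 3 (0.04 log units; within the scatter) and would lie within the scatter. For compound 3 the estimated value is 22000 nM with an expected range from 9000 nM to 50000 nM in this read-out.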

Compound 3, half-maximal inhibitory concentration: > 100000 nM
Compound 3: a limit, no number (the forecaster's own chance of this, stated with the estimate: 15%); middle value at least 4.5-fold (0.65 log units) from the limit.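

In this assay the value of compound 3 is a limit of the assay and not a number: the limit of > 100000 nM in this assay, at which 1 of the 3 values shown sits. Among the compounds shown here, the series now has a first step beyond the scatter for methoxy in place of hydrogen on this aromatic carbon, meta to a methoxy group and meta to a large group, and the step is toward weaker inhibition: an at least 4.1-fold higher number from compound 2 to compound 3 (0.61 log units; beyond the scatter). The second methoxy group does not decide the outcome alone, since compound 1 carries the same two methoxy groups and a group of 10 heavy atoms in place of a group of 6 heavy atoms on the saturated chain carbon, which gives an at least 3.4-fold higher number from compound 1 to compound 3 (0.53 log units; beyond the scatter).

The compounds shown leave open whether this step belongs to methoxy itself or would also follow from another group on the same carbon, such as fluorine, hydroxyl or an amine. They also leave open how the group of 10 heavy atoms behaves with a single methoxy group, so the two changes cannot yet be separated.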